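Swapping pyridinyl for bromophenyl on the shared core

The compounds below may be only part of what the source reports. "The series", "measured", "known", "first", "only" and "open" are said of these compounds alone.

Compound 1 `N#Cc1cccc(C(c2ccccc2)N2CCN(c3ncnc4c3cnn4-c3ccccc3)CC2)c1`: in a functional assay on cells (Rhabdomyosarcoma cell, Homo sapiens) for cytotoxicity (on this read-out lower numbers stand for stronger inhibition and higher numbers for weaker inhibition), compound 1 gives > 25000 nM, which is a limit of the assay and not a number.
Compound 2 `Cc1ccsc1C(c1ccccn1)N1CCN(c2ncnc3c2cnn3-c2ccccc2)CC1`: in this assay compound 2 gives > 25000 nM, again a limit rather than a number.

Compound 2 therefore stands at the limit, not at a measured point, and the same holds for the other value shown, since both sit at the limit of > 25000 nM in this assay, at which 2 of the 2 values shown sit. Compound 3 `Cc1ccsc1C(c1ccccc1Br)N1CCN(c2ncnc3c2cnn3-c2ccccc2)CC1` differs from compound 2 in one place: 2-bromophenyl in place of pyridin-2-yl on a saturated chain carbon bound to an amine nitrogen in a ring and an aromatic carbon. Among the measured compounds shown here, no pair of measured compounds shows what such a change does in this assay, so there is no basis for expecting a shift in either direction beyond the usual scatter. Compound 3 is therefore expected to give about 30000 nM, with a range from 8000 nM to 100000 nM. The expected step that the limit leaves unreadable from compound 2 to compound 3 amounts to no change beyond the scatter, with a limit the most likely outcome.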

Compound 3, half-maximal inhibitory concentration: > 25000 nM
Compound 3: only a limit was reported (the forecaster's own chance of this, stated with the estimate: 80%); the middle value is on the limit's open side.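

Compound 2 and compound 3 both end at a limit and not at a number, so no step between them can be read: the limit of > 25000 nM in this assay, at which 3 of the 3 values shown sit.

What the compounds shown leave open is whether 2-bromophenyl in place of pyridin-2-yl changes anything in this assay, and what actual value any of them would give there.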